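A few compounds are considered here, and "the series" means these few. Any claim that something is new, unique, unknown or untested is made for them only; others in the source may bear on it.

Compound 1 `CCCCCCC(=O)OCC(C)(C)CC1=C(O)C(=O)c2ccccc2C1=O`: 99300 nM
Compound 2 `CCCCCCCCCCC(=O)OCC(C)(C)CC1=C(O)C(=O)c2ccccc2C1=O`: > 233000 nM, a limit of the assay

Both entries come from an ADME assay on Vero cells (Chlorocebus sabaeus) for cytotoxicity, read by MTT assay; on this read-out lower numbers stand for stronger inhibition and higher numbers for weaker inhibition. Compound 2 has no number, only a limit: the limit of > 233000 nM in this assay, at which 1 of the 2 values shown sits. Compound 3 `CCCCCCCCCCCCCCCCCC(=O)OCC(C)(C)CC1=C(O)C(=O)c2ccccc2C1=O` differs from compound 2 by heptyl in place of hydrogen on a saturated chain carbon, ten or more bonds along the chain from a carbonyl carbon. Among the measured compounds shown here, one measured step bears on this change: an at least 2.3-fold higher number from compound 1 to compound 2 (0.37 log units; beyond the scatter). That step is also an extension of the chain, and its size is open-ended since it ends at a limit. A further move to a higher number is therefore expected in this assay, and the expected step is a step that the limit leaves unreadable from compound 2 to compound 3. The estimate for compound 3 is 300000 nM, with an expected range of 170000 nM to 600000 nM.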

Compound 3, half-maximal inhibitory concentration: 15500 nM
Compound 3: middle estimate off by 19-fold (1.29 log units), on the high side; the whole stated range lies above it.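

In this assay, extending the chain does not keep raising the number: heptyl in place of hydrogen on a saturated chain carbon gives an at least 15-fold lower number from compound 2 to compound 3 (1.17 log units; beyond the scatter). Against the shortest chain shown, the change still ends lower, with a 6.4-fold lower number from compound 1 to compound 3 (0.81 log units; beyond the scatter), so chain length does not move the number in one direction across these compounds. Compound 2 stands only as a limit: the limit of > 233000 nM in this assay, at which 1 of the 3 values shown sits.

Where the turn falls among chains between those of compound 2 and compound 3 stays open. So does the result for a longer chain, or for an amine in place of heptyl.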